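The compounds below may be only part of what the source reports. "The series", "measured", "known", "first", "only" and "open" are said of these compounds alone.

In a physicochemical assay for solubility, in phosphate buffer, at pH 7.4 (on this read-out lower numbers stand for lower solubility and higher numbers for higher solubility), compound 2 `O=C1/C(=C/c2cccc(C(F)(F)F)c2)CCC/C1=C\c1cccc(C(F)(F)F)c1` gives < 1000 nM, which is a limit of the assay and not a number. Compound 1 `N#CC1(c2ccccc2)C/C(=C\c2ccc(C(F)(F)F)cc2)C(=O)/C(=C/c2ccc(C(F)(F)F)cc2)C1` in this assay likewise gives < 1000 nM, again a limit. Both results sit at the same floor, (the limit of < 1000 nM in this assay, at which 2 of the 2 values shown sit). Compound 3 `CC(C)(C)C1C/C(=C\c2cccc(C(F)(F)F)c2)C(=O)/C(=C/c2cccc(C(F)(F)F)c2)C1` differs from compound 2 by tert-butyl in place of hydrogen on a saturated ring carbon. Going by the values given here, no step between measured compounds is available, so the size of this change in this assay cannot be read from the data; the expectation is no rise beyond the scatter, and most likely another limit. Compound 3 is thus estimated at 200 nM, within 30 nM to 1000 nM, an expected step that the limit leaves unreadable from compound 2 to compound 3.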

Compound 3, solubility: < 1000 nM
Compound 3 was reported as a limit; the forecaster's own chance of this, stated with the estimate: 85%; the middle value is on the limit's open side.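

In this assay compound 3 gives < 1000 nM, a limit of the assay and not a number. No step from compound 2 to compound 3 can be read, because all the results sit at one limit: the limit of < 1000 nM in this assay, at which 3 of the 3 values shown sit.

The compounds shown leave open where the actual solubility of each lies, and whether tert-butyl in place of hydrogen on a saturated ring carbon changes it.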